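Methyl for hydrogen on the ring oxygen of compound 2

This account rests on a few compounds, and the source may have more. Where it says the series, first, only, none or still open, it means among the compounds named here.

Working notes on a small pyrazole-aryl series read in a functional assay on HOP-92 cells (Homo sapiens) for inhibition, read by sulforhodamine B assay, with a stated time of 48 h; on this read-out lower numbers stand for higher toxicity in this test and higher numbers for lower toxicity in this test. Compound 1 `COc1cc(-c2nn(-c3cccc(NC(=O)c4ccc(Cl)c(C(F)(F)F)c4)c3)cc2-c2ccncc2)ccc1Cl` gives only a limit there, > 32500 nM. Compound 3 `COc1cc(-c2nn(-c3cccc(NC(=O)c4ccccc4)c3)cc2-c2ccncc2)ccc1Cl` likewise gives only a limit, > 100000 nM. Going by the values given here, the one step measured between neighbours, a step that the two limits leave unreadable from compound 1 to compound 3, is therefore not readable in size, since both ends sit at limits (the limit of > 32500 nM in this assay, at which 1 of the 3 values shown sits, (the limit of > 100000 nM in this assay, at which 1 of the 3 values shown sits)). Among the compounds with values here, compound 2 `O=C(Nc1cccc(-n2cc(-c3ccncc3)c(-c3ccc(Cl)c(O)c3)n2)c1)Nc1cc(C(F)(F)F)cc(C(F)(F)F)c1` stands as the only real number in this assay, at 8660 nM.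

Compound 4 `COc1cc(-c2nn(-c3cccc(NC(=O)Nc4cc(C(F)(F)F)cc(C(F)(F)F)c4)c3)cc2-c2ccncc2)ccc1Cl` differs from compound 2 by methyl in place of hydrogen on an oxygen on an aromatic ring. Within the data shown here, no measured step touches this change: the single measured step compares two different acyl groups on a carbonyl carbon, not the ring oxygen, and it is unreadable anyway. In this assay no movement beyond the usual scatter is therefore expected from compound 2 to compound 4, and the estimated step is a 1.4-fold higher number from compound 2 to compound 4 (0.14 log units; within the scatter). For compound 4 the expected value is 12000 nM, in a range from 4000 nM to 40000 nM.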

Compound 4, concentration lethal to 50% of the cells: 4720 nM
Compound 4: the middle estimate sits 2.5-fold (0.41 log units) above what was measured, within the range that was stated.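

In this assay, the change from 4-chloro-3-hydroxyphenyl to 4-chloro-3-methoxyphenyl gives a 1.8-fold lower number from compound 2 to compound 4 (0.26 log units; within the scatter), so hydrogen and methyl on this ring oxygen are not told apart by this read-out. Going by these compounds alone, this is the first readable step, since the only earlier step, between compound 1 and compound 3, has limits at both ends and cannot be read. Nothing at hand bears on why the two compounds read alike.

Going by these compounds, it remains open whether an ethyl group or a longer chain on this oxygen, or an amine in place of the hydroxy group, would also stay within the scatter. Also open, on these data alone, is whether the same change reads alike with the carbonyl side groups of compound 1 and compound 3.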